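The source may report more compounds than this note shows. Statements on the series, on what has been measured and on what is new or still open speak of the compounds shown alone.

Measured in a functional assay on the whole organism with Rattus norvegicus as the target; a higher number here means that more compound is needed for the effect, a lower number that less compound is needed:
- compound 1 `CC1CC(=O)NN=C1c1ccc(NC(=O)CCNCC(O)COc2ccc(CCOCC3CC3)cc2)cc1`: 1.6 umol/kg
- compound 2 `C[C@@H]1CC(=O)NN=C1c1ccc(NC(=O)CCNC[C@H](O)COc2ccc(CCOCC3CC3)cc2)cc1`: 1 umol/kg

For the measured compounds named here, the only measured step is a 1.6-fold lower number from compound 1 to compound 2 (0.20 log units; within the scatter), so compound 1 has no gap beyond the scatter on these numbers. Next is compound 3 `C[C@H]1CC(=O)NN=C1c1ccc(NC(=O)CCNC[C@@H](O)COc2ccc(CCOCC3CC3)cc2)cc1`, described as the two compounds have the same atoms and bonds; at least one stereo element is drawn with a configuration in one of them and without one in the other: 2 of 2 stereo elements differ; a stereocentre at a saturated ring carbon is drawn without a configuration in compound 1 and S in compound 3; a stereocentre at a saturated chain carbon is drawn without a configuration in compound 1 and R in compound 3. The measured step, a 1.6-fold lower number from compound 1 to compound 2 (0.20 log units; within the scatter), is the only one that bears on this, but it defines the ring carbon as R and the chain carbon as S, the opposite pairing. Going by the values given here, no measured step covers the pairing in compound 3, so a higher number is expected in this assay, with a wide range. The expected change is a 2.5-fold higher number from compound 1 to compound 3 (0.40 log units; beyond the scatter). For compound 3 the estimated value is 4 umol/kg, with an expected range of 1.2 umol/kg to 20 umol/kg.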

Compound 3, dose for half-maximal effect: > 40 umol/kg
Compound 3: no number, only a limit (the forecaster's own chance of this, stated with the estimate: 10%); middle value at least 10-fold (1.00 log units) away from the limit.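

In this assay compound 3 gives > 40 umol/kg, which is a limit of the assay and not a number. The earlier pair showed no step beyond the scatter, whereas the configuration now matters strongly, with an at least 40-fold higher number from compound 2 to compound 3 (1.60 log units; beyond the scatter) and an at least 25-fold higher number from compound 1 to compound 3 (1.39 log units; beyond the scatter). This gap rests on stereochemistry alone: the fact that compounds 2 and 3 differ only in the configuration as drawn.

The compounds shown do not separate the saturated ring carbon from the saturated chain carbon as the source of this step. On these data alone, whether an ethyl group at the ring carbon would keep the same dependence on configuration also remains open.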